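This account rests on a few compounds, and the source may have more. Where it says the series, first, only, none or still open, it means among the compounds named here.

Compound 1 `Cc1ccc([C@@H](C)Oc2cc3onc(CCC(=O)O)c3cc2Cl)nc1`: 0.31 L/kg
Compound 2 `O=C(O)CCn1c(=O)oc2cc(OCC3CC3)c(Cl)cc21`: 0.26 L/kg

In an ADME assay on the whole organism (strain Han-Wistar) for pharmacokinetics, with Rattus norvegicus as the target, read by LC-MS, at a dose of 1 mg/kg by the intravenous route (on this read-out lower numbers stand for narrower distribution and higher numbers for wider distribution into tissues), compound 1 gives 0.31 L/kg. That number lies within the usual scatter of the number for compound 2, so the two cannot be told apart. Compound 3 `C[C@@H](Oc1cc2onc(CCC(=O)O)c2cc1Cl)c1ccc(Cl)cn1` keeps the core of compound 1 and changes one group: chloro in place of methyl on an aromatic carbon. Going by the values given here, no two measured compounds differ in one place only, so the data offer no direct guide to this change. In this assay, no step beyond the scatter is expected, in either direction. The expected change is a 1.0-fold lower number from compound 1 to compound 3 (0.01 log units; within the scatter). For compound 3 the estimated value is 0.3 L/kg, with a range from 0.17 L/kg to 0.52 L/kg.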

Compound 3, volume of distribution at steady state in the Rattus norvegicus assay: 0.26 L/kg
Compound 3: the middle estimate sits 1.2-fold (0.06 log units) above what was measured, and the stated range covers the measured number.
By their numbers in the Rattus norvegicus assay, from the lowest: compounds 2, 3 and 1 (each within the scatter of the next).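

Going by these compounds alone, in the Rattus norvegicus assay, the change from 5-methylpyridin-2-yl to 5-chloropyridin-2-yl gives a 1.2-fold lower number from compound 1 to compound 3 (0.08 log units; within the scatter), the first one-place step here, and it shows no readable difference in tissue distribution at this position. In a physicochemical assay for solubility, with a stated time of 24 h (a higher number here means a more soluble compound, a lower number a less soluble compound), compound 1 gives > 860 ug/mL, a limit of the assay and not a number. In the physicochemical assay compound 3 gives > 620 ug/mL, also a limit, so the step between the two cannot be read.

As far as these compounds go, whether an amine or a methoxy group at this position would give a step beyond the scatter stays open.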